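Removing One Methoxy Group from Compound 2

The compounds below may be only part of what the source reports. "The series", "measured", "known", "first", "only" and "open" are said of these compounds alone.

Measured compounds:
compound 1, `COc1ccc(/C(Cl)=C/C=C(\C#N)C(=O)c2c[nH]c3ccc(Br)cc23)cc1` — 15.6%
compound 2, `COc1cc(/C(Cl)=C/C=C(\C#N)C(=O)c2c[nH]c3ccc(Br)cc23)cc(OC)c1OC` — 26.3%

Of the compounds shown here, two sharing the same core have been measured in a functional assay for inhibition, with a stated time of 30 min, tested at 1 mM; on this read-out higher numbers stand for more inhibition at the one concentration tested (going by the name of the read-out) and lower numbers for less inhibition. Compound 1, which carries a single methoxy group on its aromatic ring, gives 15.6%. Compound 2, which carries three methoxy groups on that ring, gives 26.3%. On these two numbers compound 2 stands highest, and its gap to compound 1 lies beyond the usual scatter of this assay.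

Compound 3 is `COc1ccc(/C(Cl)=C/C=C(\C#N)C(=O)c2c[nH]c3ccc(Br)cc23)cc1OC`, and it has not yet been measured. It differs from compound 2 in one place: hydrogen in place of methoxy on an aromatic carbon. Compound 3 therefore sits between compound 1 and compound 2 in the number of methoxy groups on its ring.

Going by the values given here, with only two measured compounds, the expectation for compound 3 rests on the two values shown. Since compound 2 gives 26.3% and compound 1 gives 15.6%, the step is expected to be downward, of modest size and possibly within the scatter, estimated as a number 5.3 percentage points lower from compound 2 to compound 3 (within the scatter). Compound 3 is thus estimated to give 21% in this assay, with a range from 8% to 34%.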

Compound 3, a percentage reported as inhibition, at one concentration (the size of the read-out at that concentration, not a potency): 11.8%
Estimate against measurement, compound 3: 9.2 percentage points above, within the range that was stated.
By their numbers in this assay, from the lowest: compounds 3 and 1 (each within the scatter of the next); then compound 2.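

In this assay the methoxy group on the aromatic carbon ortho to a methoxy group and meta to a large group now has a measured contribution: hydrogen in its place gives a number 14.5 percentage points lower from compound 2 to compound 3 (beyond the scatter) and so isolates a single change, which compound 1 and compound 2, differing in more than one place, could not do. The other single change on this ring, methoxy in place of hydrogen, gives a number 3.8 percentage points lower from compound 1 to compound 3 (within the scatter) and does not separate the two compounds, so on these compounds the two methoxy changes do not count alike. What the numbers cannot supply is any measured reason for this difference between the two changes.

The compounds shown leave open whether the read-out at this aromatic carbon depends on methoxy itself or would hold with another group there, such as ethoxy, hydroxyl, fluorine or an amine. They also leave open whether the same step would appear on a different core, since every comparison here rests on a single shared core and a single tested concentration.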